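Side-chain swap in a series with little spread

This account rests on a few compounds, and the source may have more. Where it says the series, first, only, none or still open, it means among the compounds named here.

In a functional assay on HeLa cells (Homo sapiens) for cytotoxicity, read by MTT assay (on this read-out higher numbers stand for weaker inhibition and lower numbers for stronger inhibition), compound 1 `CC(C)=CC[C@@H](OC(=O)c1ccco1)C1=CC(=O)c2c(O)ccc(O)c2C1=O` gives 80300 nM, compound 2 `CCCC(O)CC(=O)O[C@H](CC=C(C)C)C1=CC(=O)c2c(O)ccc(O)c2C1=O` gives 59300 nM, and compound 3 `COCCO[C@H](CC=C(C)C)C1=CC(=O)c2c(O)ccc(O)c2C1=O` gives 62400 nM, which lies within the scatter of both others. Compound 4 `CCC(CO[C@H](CC=C(C)C)C1=CC(=O)c2c(O)ccc(O)c2C1=O)OC(C)=O` carries 1-acetoxypropyl in place of methoxymethyl on a saturated chain carbon bound to an oxygen on a saturated carbon. The closest measured changes replace the group on that same oxygen, and they are small: a 1.3-fold lower number from compound 1 to compound 3 (0.11 log units; within the scatter) and a 1.1-fold higher number from compound 2 to compound 3 (0.02 log units; within the scatter). The remaining comparison, a 1.4-fold lower number from compound 1 to compound 2 (0.13 log units; within the scatter), is equally small. No step beyond the scatter is therefore expected. The expected change is a 1.0-fold lower number from compound 3 to compound 4 (0.00 log units; within the scatter). For compound 4 the estimated value is 62000 nM, with an expected range of 32000 nM to 115000 nM.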

Compound 4, half-maximal inhibitory concentration: 44000 nM
Compound 4: middle estimate off by 1.4-fold (0.15 log units), on the high side, and the stated range covers the measured number.
By their numbers in this assay, from the lowest: compounds 4, 2, 3 and 1 (each within the scatter of the next).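

Putting 1-acetoxypropyl in place of methoxymethyl on this saturated chain carbon gives a 1.4-fold lower number from compound 3 to compound 4 (0.15 log units; within the scatter) in this assay and so shows that this position accepts an acetoxy-bearing chain with no step beyond the scatter. With 2-acetoxybutyl on that oxygen, the comparisons with the two acyl groups also stay within the scatter, at a 1.3-fold lower number from compound 2 to compound 4 (0.13 log units; within the scatter) and a 1.8-fold lower number from compound 1 to compound 4 (0.26 log units; within the scatter) in the same read-out. No measurement here bears on why these steps are small. Going by these compounds, whether an amine or a carboxylic acid on this chain would produce a step beyond the scatter stays open.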